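Taking the methoxy off compound 3

The source may report more compounds than this note shows. Statements on the series, on what has been measured and on what is new or still open speak of the compounds shown alone.

In a functional assay on PC-3 cells (Homo sapiens) for inhibition, read by sulforhodamine B assay, with a stated time of 48 h, tested at 50 uM (on this read-out lower numbers stand for less inhibition of growth and higher numbers for more inhibition of growth at the one concentration tested), compound 1 `COc1cc(/C=C/C(=O)/C=C/c2ccco2)ccc1OCc1cn(CCCOc2cc(=O)oc3ccccc23)nn1` reads "not active" (no number reported) and compound 2 `COc1cc(/C=C/C(=O)/C=C/c2ccccc2)ccc1OCc1cn(CCCCOc2cc(=O)oc3ccccc23)nn1` reads "not active" (no number reported) without a figure. Among the compounds with values here, compound 3 `COc1cccc(/C=C/C(=O)/C=C/c2ccc(OCc3cn(CCOc4cc(=O)oc5ccccc45)nn3)c(OC)c2)c1` gives 13% and is the only one of the three with a number, so no step between measured compounds can be drawn. Compound 4 `COc1cc(/C=C/C(=O)/C=C/c2ccccc2)ccc1OCc1cn(CCOc2cc(=O)oc3ccccc23)nn1` still awaits measurement. Its structure departs from that of compound 3 by hydrogen in place of methoxy on an aromatic carbon with hydrogen in place of methoxy on an aromatic carbon, so that 3-methoxyphenyl becomes phenyl. Within the data shown here, nothing measured so far shows what this exchange does in this assay. Compound 3 at 13% sits low on the scale and leaves little room for a large fall. The expected change a number 3 percentage points lower from compound 3 to compound 4 (within the scatter) is small and slightly downward, with nothing beyond the scatter as the likeliest outcome. Compound 4 is estimated at 10% within a range from 0% to 25% and a report without a number remains possible.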

Compound 4, percent growth inhibition at one concentration: 10%
The estimate for compound 4 equals the measured number at the digits printed; the measured number falls inside the stated range.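

In this assay, within the data shown here, replacing 3-methoxyphenyl with phenyl gives a number 3 percentage points lower from compound 3 to compound 4 (within the scatter), the first step that can be read. At this place, on an aromatic carbon of a six-membered aromatic ring of carbon only and meta to a large group, hydrogen and methoxy therefore cannot be told apart at the one concentration tested, and the methoxy is not needed to keep the low reading of compound 3. No data at hand bear on the reason for this result.

Compound 1 and compound 2 carry no number, so steps to them cannot be read. On these data alone, whether an amine or a carboxylic acid at this place would move the reading beyond the scatter remains open.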